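A few compounds are considered here, and "the series" means these few. Any claim that something is new, unique, unknown or untested is made for them only; others in the source may bear on it.

Measured compounds:
compound 1 `Cc1n[nH]c(C(=O)O)c1Cc1cccc(-c2ccc(OC(F)(F)F)cc2)c1` with 300 nM
compound 2 `Cc1n[nH]c(C(=O)O)c1Cc1ccc(C(N)=O)cc1` with 1100 nM
compound 3 `Cc1n[nH]c(C(=O)O)c1Cc1ccc(-c2ccc(F)cc2)cc1` with 400 nM

All three were measured in an assay on isolated protein for inhibition of 2-Hydroxyacid oxidase 2 (Rattus norvegicus); a higher number here means a weaker inhibitor, a lower number a stronger inhibitor. Compound 1 has the lowest of the three numbers; compound 3 sits within the scatter of it, and compound 2 lies beyond the scatter above it. Compound 4 `Cc1n[nH]c(C(=O)O)c1Cc1cccc(-c2ccc(C(F)(F)F)cc2)c1` is not yet measured. It differs from compound 1 in one place: trifluoromethyl in place of trifluoromethoxy on an aromatic carbon. Within the data shown here, the only measured step, a 2.8-fold lower number from compound 2 to compound 3 (0.44 log units; beyond the scatter), concerns a different part of the molecule and does not bear on this change. Among the measured compounds shown here, no measured pair shows the effect of exchanging trifluoromethoxy for trifluoromethyl, so no step beyond the scatter is expected, giving no change at the digits printed from compound 1 to compound 4 (within the scatter). Compound 4 is therefore expected to show about 300 nM, estimated between 150 nM and 650 nM.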

Compound 4, half-maximal inhibitory concentration: 400 nM
The estimate for compound 4 lay 1.3-fold (0.12 log units) below the measured number; the measured number falls inside the stated range.
By their numbers in this assay, from the lowest: compounds 1, 3 and 4 (each within the scatter of the next); then compound 2.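

In this assay, among these compounds, exchanging trifluoromethoxy for trifluoromethyl on this aromatic carbon, para to a large group, gives a 1.3-fold higher number from compound 1 to compound 4 (0.12 log units; within the scatter) and so offers the first direct reading of this change. At this position, the loss of the oxygen and of the one hydrogen-bond acceptor counted for trifluoromethoxy leaves the number within the scatter. Nothing measured here explains this result. The compounds shown leave open whether an amine, a carboxylic acid or a methoxy group at this position would also stay within the scatter of compound 1.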